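The source may hold more compounds than are shown below. What is called first, only, known or untested is meant among the compounds shown, and "the series" means these compounds.

Compound 1 `COc1ccc(OC)c(C(=O)/C=C/c2ccco2)c1`: 10500 nM
Compound 2 `COc1ccc(OC)c(C(=O)/C=C/c2ccoc2)c1`: 18200 nM

For the measured compounds named here, in a functional assay on MCF7 cells (Homo sapiens) for cytotoxicity, read by MTT assay (on this read-out higher numbers stand for weaker inhibition and lower numbers for stronger inhibition), compound 2 gives 18200 nM, and compound 1 is its only neighbour on the numbers. The two values lie within the scatter of each other, so they cannot be ranked.

Compound 3 `COc1ccc(OC)c(C(=O)/C=C/c2cccs2)c1` has not yet been measured. It carries thiophen-2-yl in place of the furan-3-yl of compound 2, on a double-bonded chain carbon bound to a double-bonded chain carbon, and the counted difference reads thiophen-2-yl in place of furan-3-yl on a double-bonded chain carbon bound to a double-bonded chain carbon here.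

Going by the values given here, only one measured step touches this place: a 1.7-fold higher number from compound 1 to compound 2 (0.24 log units; within the scatter), for furan-3-yl in place of furan-2-yl. That step stays within the scatter, but it only exchanges one furan for another. Among the compounds with values here, no measured compound holds sulfur, so the data give no direct view of thiophen-2-yl and the direction remains open.

No step beyond the scatter is therefore expected in this assay. The estimated step is a 1.3-fold lower number from compound 2 to compound 3 (0.11 log units; within the scatter) and should not be read as a real change. For compound 3 the expected value is 14000 nM, with an estimated range from 6000 nM to 32000 nM.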

Compound 3, half-maximal inhibitory concentration: 3800 nM
Compound 3: the middle estimate sits 3.7-fold (0.57 log units) above what was measured; measured number below the stated range.
By their numbers in this assay, from the lowest: compound 3; then compounds 1 and 2 (each within the scatter of the next).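

Up to this point, the only exchange at this place, on a double-bonded chain carbon bound to a double-bonded chain carbon, swapped one furan for another, and in this assay those two compounds could not be ranked. Thiophen-2-yl is the first group here to move the number beyond the scatter, toward stronger inhibition, against both furans (a 4.8-fold lower number from compound 2 to compound 3 (0.68 log units; beyond the scatter); a 2.8-fold lower number from compound 1 to compound 3 (0.44 log units; beyond the scatter)), even though the group entering and the group leaving match in heavy-atom count, ring size and hydrogen-bond acceptors, and differ in the count only by sulfur in place of oxygen. The position therefore responds to this ring exchange, though the size of the step is modest and no available measurement speaks to why the number moves.

Still open, going by these compounds, is whether this gain is specific to thiophen-2-yl or would also appear with thiophen-3-yl, a plain phenyl ring or a pyridine ring at the same place. Equally open, on these data alone, is how the number would respond if the thiophen-2-yl ring itself carried a further group, such as a chlorine atom or a methyl group.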